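A few compounds are considered here, and "the series" means these few. Any claim that something is new, unique, unknown or untested is made for them only; others in the source may bear on it.

In a functional assay on SK-BR-3 cells (Homo sapiens) for antiproliferative activity, read by MTT assay, with a stated time of 72 h (on this read-out lower numbers stand for stronger inhibition and higher numbers for weaker inhibition), compound 2 `C/C=C1/[C@H](O[C@@H]2O[C@H](COC(C)=O)[C@@H](OC(C)=O)[C@H](OC(C)=O)[C@H]2OC(C)=O)OC=C(C(=O)OC)[C@H]1CC(=O)OCCC1CCCCC1` stands at > 15000 nM, which is a limit and not a number. Compound 1 `C/C=C1/[C@H](O[C@@H]2O[C@H](CO)[C@@H](O)[C@H](O)[C@H]2O)OC=C(C(=O)OC)[C@H]1CC(=O)OCCc1ccc2c(c1)OCCO2` is also a limit, at > 20000 nM. Compound 3 `C/C=C1/[C@H](O[C@@H]2O[C@H](CO)[C@@H](O)[C@H](O)[C@H]2O)OC=C(C(=O)OC)[C@H]1CC(=O)OCCC1CCCCC1` gives 2000 nM. The move to compound 4 `C=CCOC(=O)C[C@@H]1C(C(=O)OC)=CO[C@@H](O[C@@H]2O[C@H](COC(C)=O)[C@@H](OC(C)=O)[C@H](OC(C)=O)[C@H]2OC(C)=O)/C1=C/C` is vinyl in place of cyclohexylmethyl on a saturated chain carbon bound to an oxygen next to a carbonyl group. Going by the values given here, the one measured step on this side chain, an at least 10-fold lower number from compound 1 to compound 3 (1.00 log units; beyond the scatter), favours the cyclohexyl compound, although neither of its compounds carries the acetyl groups of compound 2. Removing that ring is therefore expected to bring no gain in this assay. The expected step is a step that the limit leaves unreadable from compound 2 to compound 4, none beyond the scatter. For compound 4 the estimated value is 20000 nM, with an expected range of 8000 nM to 50000 nM.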

Compound 4, half-maximal inhibitory concentration: > 20000 nM
Compound 4: a limit, no number; the forecaster's own chance of this, stated with the estimate: 75%; the middle value lies on the limit itself.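

Compound 2 and compound 4 both stand at limits in this assay, and the step between them cannot be read. The compounds shown leave open whether changing this side chain alters activity at all while the acetyl groups are present.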